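A methyl added to the chain of compound 2

The compounds below may be only part of what the source reports. "The series", "measured", "known", "first", "only" and "open" are said of these compounds alone.

Compound 1 `CCCCCc1ccc2[nH]c(-c3ccc(OC)cc3)c(C=O)c2c1`: 20 nM
Compound 2 `CCCCc1ccc2[nH]c(-c3ccc(OC)cc3)c(/C=N\C)c2c1`: 27 nM

In a functional assay on MCF7 cells (Homo sapiens) for antiproliferative activity, with a stated time of 5 days (on this read-out higher numbers stand for weaker inhibition and lower numbers for stronger inhibition), compound 2 at 27 nM stands level with compound 1 at 20 nM, the two values lying within the scatter of each other. Compound 3 `CCCCCc1ccc2[nH]c(-c3ccc(OC)cc3)c(/C=N\C)c2c1` has not yet been measured. It departs from compound 2 by methyl in place of hydrogen on a saturated chain carbon, four bonds along the chain from an aromatic carbon, on a saturated chain carbon, four bonds along the chain from an aromatic carbon. Going by the values given here, no measured step shows what such a change does, so no shift beyond the scatter is expected in this assay. The expected step is a 1.1-fold lower number from compound 2 to compound 3 (0.05 log units; within the scatter). Compound 3 is estimated at 24 nM, with an expected range of 11 nM to 55 nM.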

Compound 3, half-maximal inhibitory concentration: 21 nM
Estimate against measurement, compound 3: 1.1-fold (0.06 log units) above, within the range that was stated.
By their numbers in this assay, from the lowest: compounds 1, 3 and 2 (each within the scatter of the next).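

In this assay the added methyl, on a saturated chain carbon four bonds along the chain from an aromatic carbon, gives a 1.3-fold lower number from compound 2 to compound 3 (0.11 log units; within the scatter) and so stays within the scatter: the chain tolerates this extension without a readable shift. With that chain in place, replacing the carbonyl by the group of 3 heavy atoms gives a 1.1-fold higher number from compound 1 to compound 3 (0.02 log units; within the scatter) and also stays within the scatter. No evidence at hand bears on these results.

The compounds shown leave open how a longer chain, or an amine at the end of the chain, would read in this assay on this shared core.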